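A Methyl Added to a Coumarin-Indole Ester

The source may report more compounds than this note shows. Statements on the series, on what has been measured and on what is new or still open speak of the compounds shown alone.

Measured so far:
compound 1, `CCC(=O)Oc1ccc2c(C)cc(=O)oc2c1Cc1c(C)[nH]c2ccccc12`: 31000 nM
compound 2, `CCC(=O)Oc1ccc2ccc(=O)oc2c1Cc1c(-c2ccccc2)[nH]c2ccccc12`: > 100000 nM

In an ADME assay on MT4 cells (Homo sapiens) for cytotoxicity, read by MTT assay, with a stated time of 96 h (on this read-out higher numbers stand for lower toxicity in this test and lower numbers for higher toxicity in this test), compound 1 gives 31000 nM. Compound 2 yields only a limit of the assay, > 100000 nM, standing at the limit of > 100000 nM in this assay, at which 1 of the 2 values shown sits. Compound 3, `CCC(=O)Oc1ccc2c(C)cc(=O)oc2c1Cc1c(-c2ccccc2)[nH]c2ccccc12`, is still to be tested in this assay; it differs from compound 2 by methyl in place of hydrogen on an aromatic carbon. Going by the values given here, no measured pair isolates this single change, so its effect is unknown. Such a small addition is expected to move the value little, and the step of a number no higher from compound 2 to compound 3 (the limit leaves the size open) is expected to stay within the usual scatter. Compound 3 is therefore expected to give 100000 nM, between 40000 nM and 250000 nM, with a limit again likely.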

Compound 3, half-maximal cytotoxic concentration: 38000 nM
Estimate against measurement, compound 3: 2.6-fold (0.42 log units) above; measured number outside the range, below it.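

In this assay, methyl in place of hydrogen on this aromatic carbon, opposite the ring oxygen, is not a silent change: the compounds show an at least 2.6-fold lower number from compound 2 to compound 3 (0.42 log units; beyond the scatter). As far as these compounds go, the full size of that step stays open, because compound 2 gives only a limit: the limit of > 100000 nM in this assay, at which 1 of the 3 values shown sits. With this methyl present, phenyl in place of methyl on an aromatic carbon gives a 1.2-fold higher number from compound 1 to compound 3 (0.09 log units; within the scatter).

From the compounds shown here alone, whether an ethyl group, a longer chain or an amine at this position would act like methyl remains open. So does whether the methyl step would repeat with a group other than phenyl on the other aromatic carbon.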